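Trading cyano for chloro on compound 3

The source may report more compounds than this note shows. Statements on the series, on what has been measured and on what is new or still open speak of the compounds shown alone.

In an ADME assay on the whole organism (Rattus norvegicus, strain Sprague-Dawley) for pharmacokinetics, read by LC-MS, at a dose of 2 mg/kg by the oral route (a lower number here means that a smaller share of the oral dose reaches the circulation, a higher number that a larger share of the oral dose reaches the circulation), compound 1 `N#Cc1ccc(S(=O)(=O)[C@H]2CN(S(=O)(=O)c3ccc(Cl)cc3Cl)C[C@@]2(O)CO)cc1` reaches 100% while compound 2 `N#Cc1ccc(S(=O)(=O)[C@H]2CN(S(=O)(=O)c3ccc(Cl)cc3C#N)C[C@@]2(O)CO)cc1` reaches 25% and compound 3 `N#Cc1ccc(S(=O)(=O)[C@H]2CN(S(=O)(=O)c3ccc(C#N)cc3Cl)C[C@@]2(O)CO)cc1` reaches 15% on the same scale. The gap from compound 3 to its nearest neighbour is small (a number 10 percentage points lower from compound 2 to compound 3 (within the scatter)) and the gap on the other side is large (a number 85 percentage points lower from compound 1 to compound 3 (beyond the scatter)).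

Compound 4 `N#Cc1ccc(S(=O)(=O)N2C[C@H](S(=O)(=O)c3ccc(Cl)cc3)[C@](O)(CO)C2)c(Cl)c1` differs from compound 3 in one place, with chloro in place of cyano on an aromatic carbon, para to a large group, so that 4-cyanophenyl becomes 4-chlorophenyl (chloro in place of cyano on an aromatic carbon). The nearest evidence is the same exchange run the opposite way at other aromatic carbons, where cyano in place of chloro gave two large drops (a number 75 percentage points lower from compound 1 to compound 2 (beyond the scatter) and a number 85 percentage points lower from compound 1 to compound 3 (beyond the scatter)). No measurement covers this carbon itself, so a rise beyond the scatter is expected, though perhaps a smaller one (a number 35 percentage points higher from compound 3 to compound 4 (beyond the scatter)). The estimated value in this assay for compound 4 is 50% with 20% to 90% as the expected range.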

Compound 4, oral bioavailability: 100%
Beside the measured number, compound 4's estimate is 50 percentage points below it; the whole stated range lies below it.
By their numbers in this assay, from the lowest: compounds 3 and 2 (each within the scatter of the next); then compounds 1 and 4 (each within the scatter of the next).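

In this assay, the exchange proves to matter at this place too: going from 4-cyanophenyl to 4-chlorophenyl gives a number 85 percentage points higher from compound 3 to compound 4 (beyond the scatter). Until now, the exchange had been seen only at other aromatic carbons, but compound 3 now has a large step on each side, the other being a number 85 percentage points lower from compound 1 to compound 3 (beyond the scatter), so replacing either of its cyano groups with chloro leads away from its low number. The size of the exchange also carries over between different compounds: the same change on two cores in this assay, a number 75 percentage points lower (beyond the scatter) from compound 1 to compound 2 and a number 85 percentage points lower (beyond the scatter) from compound 4 to compound 3, 10 percentage points apart, within the scatter of two such steps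

Going by these compounds, whether chloro itself is needed at this place stays open, as a fluoro, a methyl or a methoxy group there could behave differently. These numbers also cannot say which part of the passage from oral dose to circulation the exchange alters.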